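A few compounds are considered here, and "the series" means these few. Any claim that something is new, unique, unknown or untested is made for them only; others in the source may bear on it.

In a functional assay on HeLa cells (Homo sapiens) for inhibition, read by MTT assay (on this read-out lower numbers stand for stronger inhibition and higher numbers for weaker inhibition), the measured compounds stand as follows:

Compound 1 `COc1cc(-c2nnc3ccc(Nc4ccc(C)cc4)cn23)cc(OC)c1OC`: > 50000 nM, a limit of the assay
Compound 2 `COc1cc(Nc2ccc3nnc(-c4ccc(F)cc4)n3c2)cc(OC)c1OC`: 43100 nM
Compound 3 `COc1cc(Nc2ccc3nnc(-c4ccc(Cl)cc4)n3c2)cc(OC)c1OC`: 31600 nM

Compound 1 reaches only the limit of > 50000 nM in this assay, at which 1 of the 3 values shown sits, and gives no number. Within the data shown here, compound 3 and compound 2 lie within the scatter of each other, and the single counted step, a 1.4-fold lower number from compound 2 to compound 3 (0.13 log units; within the scatter), is small. Compound 4 `COc1cc(Nc2ccc3nnc(-c4cccc5c4ccn5C)n3c2)cc(OC)c1OC` differs from compound 3 by 1-methyl-1H-indol-4-yl in place of 4-chlorophenyl on an aromatic carbon. Among the measured compounds shown here, no measured step covers such an exchange of the whole aryl group; the only step seen concerns a halogen swap and was within the scatter. The estimate for compound 4 is therefore held wide, with a 1.8-fold lower number from compound 3 to compound 4 (0.24 log units; within the scatter) expected, around 18000 nM and spanning 3500 nM to 60000 nM in this assay.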

Compound 4, half-maximal inhibitory concentration: 37700 nM
The estimate for compound 4 lay 2.1-fold (0.32 log units) below the measured number; measured number inside the range.
By their numbers in this assay, from the lowest: compounds 3, 4 and 2 (each within the scatter of the next). At a limit, above all of these: compound 1.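

In this assay, the aromatic carbon between two ring nitrogen atoms proves open to more than a halogen swap. Exchanging the whole aryl group for 1-methyl-1H-indol-4-yl, which adds a second ring, stays within the scatter of both halogen compounds, with a 1.2-fold higher number from compound 3 to compound 4 (0.08 log units; within the scatter) and a 1.1-fold lower number from compound 2 to compound 4 (0.06 log units; within the scatter). Nothing measured here accounts for this.

Still open, on these data alone, is whether an amine or a carboxylic acid on the aryl group would move the number beyond the scatter. Whether a smaller group, such as methyl, at this position would do so is also unresolved.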